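The source may report more compounds than this note shows. Statements on the series, on what has been measured and on what is new or still open speak of the compounds shown alone.

Working notes on the series. Compound 1 `COc1ccc(C(=O)c2sc(Nc3ccc(F)cc3)nc2N)cc1` was tested in a functional assay on MOLT-4 cells (Homo sapiens) for antiproliferative activity, read by cell counting, with a stated time of 2 days; on this read-out lower numbers stand for stronger inhibition and higher numbers for weaker inhibition. In this assay compound 1 gives only a limit, > 10000 nM. Among the measured compounds shown here, compound 2 `COc1cc(C(=O)c2sc(Nc3ccc(C)cc3)nc2N)cc(OC)c1OC` gives 21 nM in this assay, the only number among the values shown. The other value shown is the limit of > 10000 nM in this assay, at which 1 of the 2 values shown sits. Compound 3 `COc1cc(C(=O)c2sc(Nc3ccc(Cl)cc3)nc2N)cc(OC)c1OC` has not yet been measured; it differs from compound 2 by chloro in place of methyl on an aromatic carbon. For the measured compounds named here, no step between two measured compounds is available to calibrate this change, so the step is expected to be a 1.2-fold higher number from compound 2 to compound 3 (0.08 log units; within the scatter), within the scatter and in no clear direction. Compound 3 is therefore estimated at 25 nM, with a range from 8 nM to 80 nM.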

Compound 3, half-maximal inhibitory concentration: 110 nM
Compound 3: the middle estimate sits 4.4-fold (0.64 log units) below what was measured; the measured number lies above the stated range.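

The position on the 4-methylphenyl ring, para to a large group, responds to a one-atom exchange: in this assay, chloro in place of methyl gives a 5.2-fold higher number from compound 2 to compound 3 (0.72 log units; beyond the scatter). Among the compounds shown here, this is the first calibrated step, and it shows that the two groups are not interchangeable at this position. Nothing among the data shown explains this step.

As far as these compounds go, it remains open how an ethyl group or an amine at the same position would compare with methyl and chloro. A single step also leaves open whether this change would have the same size on another core.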